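The source may report more compounds than this note shows. Statements on the series, on what has been measured and on what is new or still open speak of the compounds shown alone.

Compound 3, `COc1cccc(NC2=CC(=O)c3nc4n(c3C2=O)[C@H]2OC[C@@H](O)[C@H]2OC4)c1`, is one of three compounds that share a core and differ only in the group on the amine nitrogen. In a functional assay on MGC-803 cells (Homo sapiens) for inhibition, read by sulforhodamine B assay (on this read-out higher numbers stand for weaker inhibition and lower numbers for stronger inhibition), compound 3 gives 1780 nM. Compound 1, `O=C1C=C(Nc2ccc(I)cc2)C(=O)c2c1nc1n2[C@H]2OC[C@@H](O)[C@H]2OC1`, gives 1400 nM, and compound 2, `O=C1C=C(NCc2ccccc2)C(=O)c2c1nc1n2[C@H]2OC[C@@H](O)[C@H]2OC1`, gives 2670 nM. The steps of a 1.3-fold higher number from compound 1 to compound 3 (0.10 log units; within the scatter) and a 1.5-fold lower number from compound 2 to compound 3 (0.18 log units; within the scatter) both lie within the scatter, so the three numbers cannot be told apart. Compound 4, `O=C1C=C(Nc2ccccc2)C(=O)c2c1nc1n2[C@H]2OC[C@@H](O)[C@H]2OC1`, has not yet been measured. It differs from compound 3 by hydrogen in place of methoxy on an aromatic carbon. For the measured compounds named here, no measured step removes a methoxy; the three measured swaps on that nitrogen all stayed within the scatter. A step of a 1.1-fold higher number from compound 3 to compound 4 (0.03 log units; within the scatter) is therefore expected, meaning no change beyond the scatter. Compound 4 is estimated at 1900 nM, between 900 nM and 4000 nM.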

Compound 4, half-maximal inhibitory concentration: 1730 nM
Compound 4: the middle estimate sits 1.1-fold (0.04 log units) above what was measured, and the stated range covers the measured number.
By their numbers in this assay, from the lowest: compounds 1, 4, 3 and 2 (each within the scatter of the next).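

In this assay, hydrogen in place of methoxy gives a 1.0-fold lower number from compound 3 to compound 4 (0.01 log units; within the scatter) and so makes no visible difference at this ring position. The bare phenyl group also matches the iodo-bearing ring, with a 1.2-fold higher number from compound 1 to compound 4 (0.09 log units; within the scatter) for hydrogen in place of iodo, and the benzyl group, with a 1.5-fold lower number from compound 2 to compound 4 (0.19 log units; within the scatter) for phenyl in place of benzyl, so among these compounds neither methoxy nor iodo is needed to reach this level of inhibition. Nothing available explains why these changes leave the number in place.

Still open, from the compounds shown here alone, is whether an amine or a carboxylic acid on this ring would shift the number beyond the scatter. The same question stands for a longer chain on the nitrogen.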